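Replacing an Ester with a Urea on a Dimethyltriazene

The source may report more compounds than this note shows. Statements on the series, on what has been measured and on what is new or still open speak of the compounds shown alone.

Compound 1 `CCOC(=O)c1ccc(/N=N/N(C)CC(C)C)cc1` gives 2.8 in a functional assay on L1210 cells (Mus musculus) for antiproliferative activity; on this read-out higher numbers stand for higher potency (the scale is a negative logarithm) and lower numbers for lower potency.
Compound 2 `COC(=O)c1ccc(/N=N/N(C)C)cc1` gives 3.2 in this assay.
Compound 3 `CN(C)/N=N/c1ccc(C#N)cc1C(N)=O` gives 3.46 in this assay.

Among these three, compound 2 stands second on the numbers: compound 3 lies a little higher, but that gap falls within the scatter, while compound 1 lies lower by a gap beyond the scatter. Compound 4 `CN(C)/N=N/c1ccc(NC(N)=O)cc1` has not been measured yet. It differs from compound 2 in one place: ureido in place of methoxycarbonyl on an aromatic carbon. Among the measured compounds shown here, no pair of measured compounds shows this exact change, so no measured step can be borrowed for it. The three values are all close and span only a narrow band, which gives little reason to expect a large move in either direction. Compound 4 is therefore expected to land near compound 2, with a step of a number 0.10 log units lower from compound 2 to compound 4 (within the scatter) that is not expected to exceed the scatter. The estimate for compound 4 is 3.1, with a range from 2.5 to 3.7.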

Compound 4, logarithm of the reciprocal of the active concentration, log(1/C): 3.97
Estimate against measurement, compound 4: 0.87 log units below; measured number outside the range, above it.
By their numbers in this assay, from the lowest: compound 1; then compounds 2 and 3 (each within the scatter of the next); then compound 4.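

In this assay, ureido in place of methoxycarbonyl on an aromatic carbon gives a number 0.77 log units higher from compound 2 to compound 4 (beyond the scatter), the first step read at this position, and it shows that this position can respond to a single exchange. The two groups hold the same count of 4 heavy atoms and differ in their make-up, with 2 hydrogen-bond donors in ureido against 0 in methoxycarbonyl, and 1 hydrogen-bond acceptor against 2. Nothing available explains the rise, and this one pair cannot separate the contributions of those differences.

An amine or a carboxylic acid at the same place on the shared core would show whether the rise is particular to ureido. From the compounds shown here alone, whether the same exchange carries over to a core with a longer chain on the triazene also remains open.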